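A Benzyloxy Addition Tested for Cytotoxicity in Kidney Cells

This account rests on a few compounds, and the source may have more. Where it says the series, first, only, none or still open, it means among the compounds named here.

Compound 1 `Cc1cc(O)c(C(=O)/C=C/c2ccccc2)c(-c2ccccc2)c1C(=O)/C=C/c1ccccc1`: "not active" (no number reported)
Compound 2 `Cc1cc(O)c(C(=O)/C=C/c2ccc(Cl)cc2)c(-c2ccccc2)c1C(=O)/C=C/c1ccc(Cl)cc1`: 10000 nM

Of the compounds shown here, two have been measured in an ADME assay on HEK293 cells (Homo sapiens) for cytotoxicity, read by MTT assay, with a stated time of 24 h; on this read-out higher numbers stand for weaker inhibition and lower numbers for stronger inhibition. Compound 1 gives "not active" (no number reported), so no single number stands for compound 1 in this assay. Compound 2 gives 10000 nM. Compound 3 `Cc1cc(O)c(C(=O)/C=C/c2ccccc2)c(-c2ccc(OCc3ccccc3)cc2)c1C(=O)/C=C/c1ccccc1` has not been measured; it differs from compound 1 by benzyloxy in place of hydrogen on an aromatic carbon. Among the measured compounds shown here, no measured pair isolates this change, so the data show nothing about how large a shift to expect or in which direction. Because compound 1 gives "not active" (no number reported), a weak effect is expected again. Compound 3 is expected to give 15000 nM, within a range from 5000 nM to 50000 nM.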

Compound 3, half-maximal inhibitory concentration: "not active" (no number reported)
Compound 3 has no reported number here; the estimate stays without a comparison.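

Compound 1 and compound 3 both come back as "not active" (no number reported) in this assay, so no step can be read between them. No measurement here bears on a cause for this result. The compounds shown leave open what the benzyloxy group does to cytotoxicity in these cells.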